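Selenocyanate carbamates: propyl to benzyl ester step

The source may hold more compounds than are shown below. What is called first, only, known or untested is meant among the compounds shown, and "the series" means these compounds.

Measured so far in a functional assay on PC-3 cells (Homo sapiens) for cytotoxicity, read by MTT assay, with a stated time of 72 h; a higher number here means a weaker inhibitor of growth, a lower number a stronger inhibitor of growth:
- compound 1 `CCCOC(=O)Nc1ccc([Se]C#N)cc1` gives 21100 nM
- compound 2 `Cc1ccc(OC(=O)Nc2ccc([Se][Se]c3ccc(NC(=O)Oc4ccc(C)cc4)cc3)cc2)cc1` gives 4400 nM
- compound 3 `N#C[Se]c1ccc(NC(=O)Oc2ccc(Cl)cc2)cc1` gives 6400 nM

Compound 1 stands at the highest of the three numbers in this assay, that is, as the weakest inhibitor of growth among them. The nearest measured number is that of compound 3, which lies lower by a margin beyond the scatter; compound 2 lies lower still, also beyond the scatter. Among the measured compounds shown here, no pair of these three differs in only one place, so no single step between measured compounds can be read off.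

Compound 4 `N#C[Se]c1ccc(NC(=O)OCc2ccccc2)cc1` is the next compound to be measured. Relative to compound 1 the change is phenyl in place of ethyl on a saturated chain carbon bound to an oxygen next to a carbonyl group. The shared core, the selenocyanate-bearing ring with its carbamate nitrogen, is kept.

Nothing measured yet isolates this exact change, so the expectation rests only on where compound 1 stands and on the lower numbers of compound 2 and compound 3. A step toward a lower number is expected, of modest size, near the edge of the scatter: a 2.1-fold lower number from compound 1 to compound 4 (0.32 log units; beyond the scatter). Compound 4 is therefore estimated at 10000 nM in this assay, with a range from 4000 nM to 25000 nM.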

Compound 4, concentration for 50% growth inhibition: 3700 nM
Estimate against measurement, compound 4: 2.7-fold (0.43 log units) above; the measured number lies below the stated range.
By their numbers in this assay, from the lowest: compounds 4, 2 and 3 (each within the scatter of the next); then compound 1.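

Among the compounds shown here, compound 4 gives the first single-place step: in this assay, the change of phenyl in place of ethyl on a saturated chain carbon bound to an oxygen next to a carbonyl group gives a 5.7-fold lower number from compound 1 to compound 4 (0.76 log units; beyond the scatter), with the shared core kept. This shows that the number in this assay responds to a change at this place alone, which compounds 1, 2 and 3 could not show, as no two of them differ in only one place. The step joins the arrival of an aromatic ring and a rise in heavy atoms in one change, and no measured result that bears on its cause is available.

The compounds shown leave open whether the ring itself matters, or whether a longer chain such as hexyl at the same place would give a similar number. They also leave open how an amine or a carboxylic acid on the phenyl group would alter the number, so this single step defines no trend at this position.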